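The source may hold more compounds than are shown below. What is called first, only, known or untested is meant among the compounds shown, and "the series" means these compounds.

Measured compounds:
- compound 1 `c1ccc(-c2nc3ccccn3c2NCC2CCO2)nc1`: > 50000 nM
- compound 2 `COc1ccn2c(Nc3ccccc3F)c(-c3ccccn3)nc2c1`: 5750 nM

In an ADME assay on THP-1 cells (Homo sapiens) for cytotoxicity (on this read-out higher numbers stand for lower toxicity in this test and lower numbers for higher toxicity in this test), compound 1 gives > 50000 nM, which is a limit of the assay rather than a number, as noted in the limit of > 50000 nM in this assay, at which 1 of the 2 values shown sits. Compound 2 gives 5750 nM in this assay. Compound 3 `N#Cc1ccc(Nc2c(-c3ccccn3)nc3ccccn23)cc1` is not yet measured; it differs from compound 1 by 4-cyanophenyl in place of (oxetan-2-yl)methyl on a nitrogen on an aromatic ring. Among the compounds with values here, no measured step covers this change, so the expected step from compound 1 to compound 3 is an at least 6.2-fold lower number from compound 1 to compound 3 (0.79 log units; beyond the scatter), downward, toward higher toxicity. Compound 3 is expected at 8000 nM with a range of 2000 nM to 50000 nM, because compound 2 gives 5750 nM.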

Compound 3, half-maximal cytotoxic concentration: > 50000 nM
Compound 3 gave a limit, no number; the forecaster's own chance of this, stated with the estimate: 30%; middle value at least 6.2-fold (0.79 log units) away from the limit.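

In this assay, within the data shown here, compound 1 and compound 3 both stop at a limit rather than a number, so no step between them can be read: the limit of > 50000 nM in this assay, at which 2 of the 3 values shown sit.

From the compounds shown here alone, how 4-cyanophenyl and (oxetan-2-yl)methyl truly compare on this read-out stays open.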